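The source may report more compounds than this note shows. Statements on the series, on what has been measured and on what is new or still open speak of the compounds shown alone.

Measured compounds and their readings in an ADME assay on a cell-free system (plasma, Homo sapiens) for metabolic stability, read by LC-MS, with a stated time of 60 min, at 37 degrees C, tested at 50 uM; a higher number here means that more of the compound is left, a lower number that less of the compound is left:

compound 1, `C[C@@H](O)[C@H]1C(=O)N2C(C(=O)OCOC(=O)C3CCCCC3)=C(S[C@@H]3CN[C@H](C(=O)Nc4cccc(C(=O)O)c4)C3)[C@H](C)[C@H]12`, gives 20%
compound 2, `CCOC(=O)OCOC(=O)C1=C(S[C@@H]2CN[C@H](C(=O)Nc3cccc(C(=O)O)c3)C2)[C@H](C)[C@@H]2[C@@H]([C@@H](C)O)C(=O)N12`, gives 10%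
compound 3, `C[C@@H](O)[C@H]1C(=O)N2C(C(=O)OCOC(=O)OC3CCCCC3)=C(S[C@@H]3CN[C@H](C(=O)Nc4cccc(C(=O)O)c4)C3)[C@H](C)[C@H]12`, gives 46%

Compound 3 stands highest of the three: the step of a number 26 percentage points higher from compound 1 to compound 3 (beyond the scatter) lies beyond the scatter, as does the step of a number 36 percentage points higher from compound 2 to compound 3 (beyond the scatter), whereas the step of a number 10 percentage points lower from compound 1 to compound 2 (within the scatter) stays within it.

Compound 4, `C[C@@H](O)[C@H]1C(=O)N2C(C(=O)OCOC(=O)OC3CCCCC3)=C(S[C@@H]3CN[C@H](C(=O)Nc4cccc(C(=O)OCOC(=O)OC5CCCCC5)c4)C3)[C@H](C)[C@H]12`, differs from compound 3 in one place: ((cyclohexyloxycarbonyl)oxy)methyl in place of hydrogen on an oxygen next to a carbonyl group. The measured steps do not reproduce this change. Among the measured compounds shown here, they vary the group on the other ester carbonyl, and only the step of a number 36 percentage points higher from compound 2 to compound 3 (beyond the scatter) involves a cyclohexyl entering in a comparable fashion. None of them adds a second ((cyclohexyloxycarbonyl)oxy)methyl where a hydrogen stood. For the measured compounds named here, with two such groups now present in compound 4 and no measured step for guidance, a step downward is expected in this assay, though its size is uncertain; the expected step is a number 16 percentage points lower from compound 3 to compound 4 (beyond the scatter). Compound 4 is therefore estimated at 30%, with a range from 10% to 60%.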

Compound 4, percent of the compound remaining: 96%
Beside the measured number, compound 4's estimate is 66 percentage points below it; the measured number lies above the stated range.
By their numbers in this assay, from the lowest: compounds 2 and 1 (each within the scatter of the next); then compound 3; then compound 4.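

On an oxygen next to a carbonyl group, ((cyclohexyloxycarbonyl)oxy)methyl in place of hydrogen brings a number 50 percentage points higher from compound 3 to compound 4 (beyond the scatter) in this assay. This position, which compound 1, compound 2 and compound 3 all leave as hydrogen, therefore bears strongly on how much compound is left, and compound 4, with a second copy of the group, stands highest of the four. Nothing at hand bears on why the change has this effect.

As far as these compounds go, it remains open whether this rise needs the whole ((cyclohexyloxycarbonyl)oxy)methyl group or would also follow from a plain methyl or an acetoxymethyl on the same oxygen. From the compounds shown here alone, it also remains open whether the rise would hold if the group on the other ester carbonyl were the ethoxy of compound 2 or the cyclohexyl of compound 1.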